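Phenyl to chlorofuranyl exchange in the ether series

A few compounds are considered here, and "the series" means these few. Any claim that something is new, unique, unknown or untested is made for them only; others in the source may bear on it.

Measured so far, in a functional assay on HT-29 cells (Homo sapiens) for cytotoxicity, read by MTT assay, with a stated time of 48 h; a higher number here means a weaker inhibitor, a lower number a stronger inhibitor:
compound 1 `O=C1C[C@H](OCc2cn(-c3ccccc3)nn2)[C@H]2CO[C@@H]1O2` gives 13400 nM
compound 2 `O=C1C[C@H](OCc2cc(-c3ccccc3)no2)[C@H]2CO[C@@H]1O2` gives 16900 nM

Compound 2 holds the highest of the two numbers in this assay; its nearest neighbour is compound 1, and the two values lie within the scatter of each other, so no order between them is claimed. Compound 3 `O=C1C[C@H](OCc2cc(-c3ccc(Cl)o3)no2)[C@H]2CO[C@@H]1O2` has not yet been measured. It differs from compound 2 in one place: 5-chlorofuran-2-yl in place of phenyl on an aromatic carbon. Among the compounds with values here, no step between measured compounds is known for this kind of change, and two numbers this close give no pattern to lean on. The step from compound 2 to compound 3 in this assay is expected to stay small, with no direction beyond the scatter: a 1.2-fold lower number from compound 2 to compound 3 (0.08 log units; within the scatter). Compound 3 is estimated at 14000 nM in this assay, with a range from 5000 nM to 40000 nM.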

Compound 3, half-maximal inhibitory concentration: 10100 nM
Estimate against measurement, compound 3: 1.4-fold (0.14 log units) above; the measured number falls inside the stated range.
By their numbers in this assay, from the lowest: compounds 3, 1 and 2 (each within the scatter of the next).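

In this assay, within the data shown here, the aromatic carbon of the five-membered aromatic ring with 1 nitrogen and 1 oxygen takes 5-chlorofuran-2-yl in place of phenyl with a 1.7-fold lower number from compound 2 to compound 3 (0.22 log units; within the scatter) as the only step read at this position. Within this pair, then, exchanging a six-membered aromatic ring of carbon only for a five-membered aromatic ring with 1 hetero atom and a chlorine, at an equal heavy-atom count, leaves the reading inside the scatter. No measurement on hand accounts for this result.

Still open, as far as these compounds go, is whether a group of another kind at this position, such as a primary amine or a carboxylic acid, would give a step beyond the scatter. Also open, from the compounds shown here alone, is what the chlorine contributes on its own, which would take a plain furan-2-yl counterpart of compound 3 to read.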